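Chloro to dimethylamino and its effect on cytotoxicity

A few compounds are considered here, and "the series" means these few. Any claim that something is new, unique, unknown or untested is made for them only; others in the source may bear on it.

Compound 1 `O=C1/C(=C/c2ccc(Cl)cc2)CCC/C1=C\c1ccccc1[N+](=O)[O-]` and compound 3 `O=C1/C(=C/c2ccc(Cl)cc2)CCC/C1=C\c1ccc([N+](=O)[O-])cc1` contain the same atoms joined differently; the difference between the two cores is not broken down here. In a functional assay on HL-60 cells (Homo sapiens) for cytotoxicity, with a stated time of 24 h (on this read-out lower numbers stand for higher toxicity in this test and higher numbers for lower toxicity in this test), compound 1 gives 7600 nM. In this assay compound 3 gives 4100 nM, and the two numbers lie within the scatter of each other. Compound 2 `CN(C)c1ccc(/C=C2\CCC/C(=C\c3ccccc3[N+](=O)[O-])C2=O)cc1` carries the change dimethylamino in place of chloro on an aromatic carbon relative to compound 1. The value of compound 2 in this assay is a limit, > 400000 nM. The step of an at least 52-fold higher number from compound 1 to compound 2 (1.72 log units; beyond the scatter) is accordingly bounded by the limit of > 400000 nM in this assay, at which 1 of the 3 values shown sits, so only its lower end is known.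

Compound 4 `CN(C)c1ccc(/C=C2\CCC/C(=C\c3ccc([N+](=O)[O-])cc3)C2=O)cc1` has not been measured. Its difference from compound 3 is dimethylamino in place of chloro on an aromatic carbon, the same change as made from compound 1 to compound 2, at a place described in the same words. The expectation for compound 4 rests on the pair compound 1 and compound 2, where this change gave an at least 52-fold higher number from compound 1 to compound 2 (1.72 log units; beyond the scatter), and on the fact that compound 1 and compound 3 sit within the scatter of each other, compound 3 giving 4100 nM. Compound 4 is therefore expected to give 400000 nM in this assay, most likely reported as a limit rather than a number, with a plausible range from 100000 nM to 2000000 nM. The estimated step is a 98-fold higher number from compound 3 to compound 4 (1.99 log units; beyond the scatter).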

Compound 4, half-maximal cytotoxic concentration: > 400000 nM
Compound 4 gave a limit, no number (the forecaster's own chance of this, stated with the estimate: 75%); the middle value sits exactly at the limit.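

Dimethylamino in place of chloro has now been followed on two cores, and on the core of compound 3 it gives an at least 97-fold higher number from compound 3 to compound 4 (1.98 log units; beyond the scatter) in this assay. The change therefore moves the read-out in the same direction, beyond the scatter, on both cores shown, with the number rising each time: the same change on two cores in this assay, an at least 52-fold higher number (1.72 log units; beyond the scatter) from compound 1 to compound 2 and an at least 97-fold higher number (1.98 log units; beyond the scatter) from compound 3 to compound 4; the limit leaves it open whether they differ. As far as these compounds go, the true size of the step remains unknown on either core, and the step between compound 2 and compound 4, where the nitrophenyl group differs, cannot be read, as both compounds stop at the same assay limit: the limit of > 400000 nM in this assay, at which 2 of the 4 values shown sit.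

Still open, from the compounds shown here alone, is how far the result is tied to dimethylamino itself, as only chloro and dimethylamino are compared here; a primary amine, a methoxy group or a plain hydrogen in the same place would show whether the sharp rise in the number extends beyond this one group. It is also open whether the same change carries over to a core in which a nitrile or a carboxylic acid takes the place of the nitro group, as every compound shown keeps a nitrophenyl group.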